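The source may hold more compounds than are shown below. What is called first, only, known or untested is meant among the compounds shown, and "the series" means these compounds.

Working notes on the series. Compound 1 `COc1cc2ncnc(NNC(=S)NC(=O)c3ccccc3Cl)c2cc1OC` and compound 2 `COc1cc2ncnc(NNC(=S)NC(=O)c3ccc(C)cc3)c2cc1OC` share one core and differ only in the aryl group on the carbonyl carbon. In a functional assay on MCF7 cells (Homo sapiens) for cytotoxicity, read by MTT assay, with a stated time of 72 h (on this read-out lower numbers stand for stronger inhibition and higher numbers for weaker inhibition), compound 1 gives 23100 nM and compound 2 gives 22300 nM. The step of a 1.0-fold lower number from compound 1 to compound 2 (0.02 log units; within the scatter) shows that swapping 2-chlorophenyl for 4-methylphenyl leaves the read-out essentially unchanged. Compound 2 therefore holds the lower of the two numbers, but sits within the scatter of compound 1, so no order between them is claimed.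

Compound 3 `COc1cc2ncnc(NNC(=S)NC(=O)c3ccccc3)c2cc1OC` is not yet measured. It differs from compound 2 by hydrogen in place of methyl on an aromatic carbon. For the measured compounds named here, the only measured step that bears on this is the aryl exchange a 1.0-fold lower number from compound 1 to compound 2 (0.02 log units; within the scatter), which stayed within the scatter, so for this assay no step beyond the scatter is expected here either. Compound 3 is accordingly estimated at 22000 nM, with a range from 11000 nM to 44000 nM; the expected step is a 1.0-fold lower number from compound 2 to compound 3 (0.01 log units; within the scatter).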

Compound 3, half-maximal inhibitory concentration: 6990 nM
Compound 3: the middle estimate sits 3.1-fold (0.50 log units) above what was measured; measured number below the stated range.
By their numbers in this assay, from the lowest: compound 3; then compounds 2 and 1 (each within the scatter of the next).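

In this assay, hydrogen in place of methyl on the aromatic carbon para to a large group gives a modest step (a 3.2-fold lower number from compound 2 to compound 3 (0.50 log units; beyond the scatter)), and hydrogen in place of chloro gives one of similar printed size (a 3.3-fold lower number from compound 1 to compound 3 (0.52 log units; beyond the scatter)). The exchange of one substituted aryl group for the other had stayed within the scatter, whereas the phenyl of compound 3 stands apart from both, so among these three compounds the lower number goes with the ring bearing neither methyl nor chloro, and none goes against this. Nothing available explains this difference.

Two substituents cannot show whether any group on this ring raises the number. An amine or a carboxylic acid on the carbon bearing methyl in compound 2 would test whether the step holds beyond methyl and chloro.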